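This account rests on a few compounds, and the source may have more. Where it says the series, first, only, none or still open, it means among the compounds named here.

Measured in a functional assay on KYSE-70 cells for antiproliferative activity against KYSE-70 cell line (Homo sapiens), read by MTT assay, with a stated time of 72 h (on this read-out lower numbers stand for stronger inhibition and higher numbers for weaker inhibition), so far:
- compound 1 `O=C(Nc1cccc(F)c1)c1cc(=O)[nH]c2cc(Br)ccc12` at 8900 nM
- compound 2 `O=C(Nc1cccc(Cl)c1)c1cc(=O)[nH]c2cc(Br)ccc12` at > 20000 nM (a limit of the assay, not a number)
- compound 3 `O=C(Nc1cc(F)cc(F)c1)c1cc(=O)[nH]c2cc(Br)ccc12` at 10700 nM

Not yet measured: compound 4 `COc1ccc(-c2ccc3c(C(=O)Nc4cccc(F)c4)cc(=O)[nH]c3c2)cc1`

For the measured compounds named here, compound 1 stands at the low end of the series, level with the only other number. That gap is a 1.2-fold higher number from compound 1 to compound 3 (0.08 log units; within the scatter) and counts as no change. Going by the values given here, the chloro swap gives an at least 2.2-fold higher number from compound 1 to compound 2 (0.35 log units; beyond the scatter) and is the only step beyond the scatter. Neither step touches the bromo position, so neither measures the change now in question. Compound 4 puts 4-methoxyphenyl in place of bromo on an aromatic carbon, counted as 4-methoxyphenyl in place of bromo on an aromatic carbon, and this is a far larger change than either measured step. Compound 2 reports only a limit. Compound 1 at 8900 nM has little measurable room upward, so a moderate step to a lower number is expected in this assay, with wide uncertainty. Estimated step: a 3.0-fold lower number from compound 1 to compound 4 (0.47 log units; beyond the scatter). For compound 4 the expected value is 3000 nM, with an estimated range of 500 nM to 15000 nM.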

Compound 4, half-maximal inhibitory concentration: > 20000 nM
Compound 4 was reported as a limit (the forecaster's own chance of this, stated with the estimate: 15%); middle value at least 6.6-fold (0.82 log units) away from the limit.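

In this assay, for the compounds shown here, the bromo position proves sensitive to change, which the earlier steps could not show because they left it untouched: 4-methoxyphenyl in place of bromo gives an at least 2.2-fold higher number from compound 1 to compound 4 (0.35 log units; beyond the scatter). For compound 4, > 20000 nM is a limit of the assay and not a number. This replacement, with its added six-membered aromatic ring, brings no gain at this position, and the full size of the loss cannot be read: the limit of > 20000 nM in this assay, at which 2 of the 4 values shown sit.

Still open, on these data alone, is whether an unsubstituted phenyl, a methyl group or an amine in place of bromo would keep or lower the number. Also open, as far as these compounds go, is whether the 4-methoxyphenyl result holds with other groups on the far side of the amide.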